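Piperidin-1-yl to 5-Chloro-2-fluorophenyl: Expected Vero Cell Toxicity

A few compounds are considered here, and "the series" means these few. Any claim that something is new, unique, unknown or untested is made for them only; others in the source may bear on it.

compound 1 `C[C@]1(CN2CCc3nc(N4CCCCC4)ccc3C2)Cn2cc([N+](=O)[O-])nc2O1` — "not determined" (no result reported)
compound 2 `C[C@]1(CN2CCc3nc(-c4ccc(F)c(F)c4)ccc3C2)Cn2cc([N+](=O)[O-])nc2O1` — > 32 ug/mL
compound 3 `C[C@]1(CN2CCc3nc(-c4ccc(Cl)cc4F)ccc3C2)Cn2cc([N+](=O)[O-])nc2O1` — > 32 ug/mL

Three compounds share one core and differ only in the group attached to it. In an ADME assay on Vero cells (Chlorocebus sabaeus) for cytotoxicity, read by MTT assay, with a stated time of 72 h (on this read-out lower numbers stand for higher toxicity in this test and higher numbers for lower toxicity in this test), compound 1 has no reported result, "not determined" (no result reported), so it stands nowhere on the numbers shown. Compound 2 gives only a limit of this assay, > 32 ug/mL. Compound 3 likewise gives only a limit, > 32 ug/mL. The step that the two limits leave unreadable from compound 2 to compound 3 therefore cannot be read.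

Compound 4 `C[C@]1(CN2CCc3nc(-c4cc(Cl)ccc4F)ccc3C2)Cn2cc([N+](=O)[O-])nc2O1` differs from compound 1 by 5-chloro-2-fluorophenyl in place of piperidin-1-yl on an aromatic carbon. Among the compounds with values here, no measured step follows this same change, so no size or direction can be taken from a measured pair. What the data do show is the limit of > 32 ug/mL in this assay, at which 2 of the 3 values shown sit, reached by both compounds carrying a fluorinated and chlorinated phenyl group.

On that basis compound 4 is expected to sit near 40 ug/mL, within 20 ug/mL to 80 ug/mL, most likely again reported only as a limit.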

Compound 4, half-maximal cytotoxic concentration: > 32 ug/mL
Compound 4 was reported as a limit; the forecaster's own chance of this, stated with the estimate: 75%; the middle value does not contradict the limit.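

In this assay, within the data shown here, compound 2, compound 3 and compound 4 are all reported only as a limit, so no step among them can be read. Left open is how far apart these three truly stand, and whether moving or swapping the halogens on the phenyl group changes the result at all.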